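A few compounds are considered here, and "the series" means these few. Any claim that something is new, unique, unknown or untested is made for them only; others in the source may bear on it.

Measured so far:
Compound 1 `CN1CCN(Cc2csc(N)c2C(=O)c2ccc(Cl)cc2)CC1` — 1.7 nM
Compound 2 `Nc1scc(CN2CCN(c3ccc(F)cc3)CC2)c1C(=O)c1ccc(Cl)cc1` — 1.8 nM
Compound 3 `N#Cc1ccc(N2CCN(Cc3csc(N)c3C(=O)c3ccc(Cl)cc3)CC2)cc1` — 1.8 nM

In an assay on CHO cells for displacement of a labelled ligand from adenosine receptor A1 (Homo sapiens) (a higher number here means weaker binding, a lower number tighter binding), compound 3 gives 1.8 nM, and the three values lie within the scatter of each other: a 1.1-fold higher number from compound 1 to compound 3 (0.02 log units; within the scatter) and no change at the digits printed from compound 2 to compound 3 (within the scatter). Compound 4 `Nc1scc(CN2CCN(c3ncccn3)CC2)c1C(=O)c1ccc(Cl)cc1` differs from compound 3 in one place: pyrimidin-2-yl in place of 4-cyanophenyl on an amine nitrogen in a ring. Among the compounds with values here, the steps that bear on it are those that changed the group on the same ring nitrogen, a 1.1-fold higher number from compound 1 to compound 2 (0.02 log units; within the scatter) and a 1.1-fold higher number from compound 1 to compound 3 (0.02 log units; within the scatter), together with the swap on the aromatic carbon, no change at the digits printed from compound 2 to compound 3 (within the scatter); none of them left the scatter. The step of a 1.1-fold higher number from compound 3 to compound 4 (0.02 log units; within the scatter) is therefore expected to stay within the scatter. Compound 4 is estimated at 1.9 nM, with a range of 0.9 nM to 4.5 nM in this assay.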

Compound 4, dissociation constant: 1.7 nM
The estimate for compound 4 lay 1.1-fold (0.05 log units) above the measured number; the range from low to high includes it.
By their numbers in this assay, from the lowest: compounds 1, 4, 2 and 3 (each within the scatter of the next).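

A ring with 2 hetero atoms on this amine nitrogen reads the same in this assay as the carbon-only aromatic rings and methyl do (3 to 4: a 1.1-fold lower number from compound 3 to compound 4 (0.02 log units; within the scatter); 2 to 4: a 1.1-fold lower number from compound 2 to compound 4 (0.02 log units; within the scatter); 1 to 4: no change at the digits printed from compound 1 to compound 4 (within the scatter)). All four groups thus lie within the scatter, now including one with no substituent on its ring. Nothing offered explains this flat response. On these data alone, whether a carboxylic acid, a primary amine or a longer chain on this nitrogen would move the number remains open.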